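A few compounds are considered here, and "the series" means these few. Any claim that something is new, unique, unknown or untested is made for them only; others in the source may bear on it.

Measured so far:
Compound 1 `COc1cc2ncnc(-n3nc(Nc4ccc(N5CCN(C6CC7CCC6C7)CC5)c(Cl)c4)nc3N)c2cc1OC` gives 117 mL/min/kg in an ADME assay on the whole organism (strain Sprague-Dawley) for pharmacokinetics, with Rattus norvegicus as the target; on this read-out lower numbers stand for slow clearance and higher numbers for fast clearance.
Compound 2 `Cc1nc(-n2nc(Nc3ccc(N4CCN(C5CC6CCC5C6)CC4)cc3)nc2N)c2ccccc2n1` gives "not determined" (no result reported) in this assay.
Compound 3 `Nc1nc(Nc2ccc(N3CCN(C4CC5CCC4C5)CC3)cc2)nn1-c1nccc2ccccc12` gives 52 mL/min/kg in this assay.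

Among the two numbers available, compound 3 has the lower one; the number for compound 1 is higher, by a gap beyond the usual scatter of repeated measurements. Compound 2 has no result to compare.

Compound 4 `Cc1csc2c(-n3nc(Nc4ccc(N5CCN(C6CC7CCC6C7)CC5)cc4)nc3N)nc(Cl)nc12` has not yet been measured in this assay. It differs from compound 3 in one place: a group of 11 heavy atoms (7 carbon, 2 nitrogen, 1 sulfur, 1 chlorine; one five-membered aromatic ring with 1 hetero atom, one six-membered aromatic ring with 2 hetero atoms) in place of a group of 10 heavy atoms (9 carbon, 1 nitrogen; one six-membered aromatic ring of carbon only, one six-membered aromatic ring with 1 hetero atom), on an aromatic nitrogen.

Among the measured compounds shown here, no measured pair shows this change, so the size of the step is uncertain; a small rise is expected, not beyond the scatter, a 1.3-fold higher number from compound 3 to compound 4 (0.13 log units; within the scatter). Compound 4 is therefore estimated at 70 mL/min/kg, with an expected range from 30 mL/min/kg to 150 mL/min/kg.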

Compound 4, clearance: 11.5 mL/min/kg
The estimate for compound 4 lay 6.1-fold (0.78 log units) above the measured number; measured number outside the range, below it.
By their numbers in this assay, from the lowest: compound 4; then compound 3; then compound 1.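

On an aromatic nitrogen, replacing isoquinolin-1-yl with the group holding sulfur and chlorine gives a 4.5-fold lower number from compound 3 to compound 4 (0.66 log units; beyond the scatter) in this assay. This shows that the group at this position can shift clearance beyond the usual scatter, here towards slower clearance. Nothing measured here accounts for the step.

On these data alone, the chlorine and the ring atoms changed together, so the share of each remains unknown. As far as these compounds go, whether a morpholine in place of the chlorine would keep clearance this slow also remains open.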